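Extending the methyl group of compound 3

The source may report more compounds than this note shows. Statements on the series, on what has been measured and on what is new or still open speak of the compounds shown alone.

Three compounds sharing one core differ in the group carried on an aromatic carbon. In a functional assay on MV4-11 cells (Homo sapiens) for inhibition, read by resazurin assay, with a stated time of 72 h (on this read-out lower numbers stand for stronger inhibition of growth and higher numbers for weaker inhibition of growth), compound 1 (`O=C1NCCC12CCN(c1c(Cl)cncc1-c1cccs1)CC2`), with thiophen-2-yl, gives 480 nM, compound 2 (`O=C1NCCC12CCN(c1c(Cl)cncc1-c1cc[nH]c1)CC2`), with 1H-pyrrol-3-yl, gives 1050 nM, and compound 3 (`Cc1ccc(-c2cncc(Cl)c2N2CCC3(CCNC3=O)CC2)o1`), with 5-methylfuran-2-yl, gives 4950 nM, the highest number of the three. Compound 4 (`CCOCOCc1ccc(-c2cncc(Cl)c2N2CCC3(CCNC3=O)CC2)o1`) differs from compound 3 in one place: ethoxymethoxy in place of hydrogen on a saturated chain carbon bound to an aromatic carbon. Its methyl thus becomes (ethoxymethoxy)methyl.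

The measured steps bear on this change only indirectly. Both steps that end at the 5-methylfuran-2-yl group raise the number: a 10-fold higher number from compound 1 to compound 3 (1.01 log units; beyond the scatter) is large and a 4.7-fold higher number from compound 2 to compound 3 (0.67 log units; beyond the scatter) is modest. The remaining step, a 2.2-fold higher number from compound 1 to compound 2 (0.34 log units; beyond the scatter), is also modest. All three exchange the whole group, and none alters the methyl or the chain carbon that carries the new group. They show that this assay responds to this group, but they do not measure the present change. A step beyond the scatter is therefore not firmly expected, with only a slight lean toward a higher number. The expected change is a 1.3-fold higher number from compound 3 to compound 4 (0.12 log units; within the scatter). For compound 4 the estimated value is 6500 nM, with an expected range from 2000 nM to 20000 nM.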

Compound 4, concentration for 50% growth inhibition: 2970 nM
Compound 4: the middle estimate sits 2.2-fold (0.34 log units) above what was measured; the range from low to high includes it.
By their numbers in this assay, from the lowest: compound 1; then compound 2; then compounds 4 and 3 (each within the scatter of the next).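

Among the compounds shown, this is the first step that leaves the rest of the 5-methylfuran-2-yl group untouched and alters only its methyl, so it is the first direct reading at this saturated chain carbon bound to an aromatic carbon. In this assay, the step of a 1.7-fold lower number from compound 3 to compound 4 (0.22 log units; within the scatter) does not separate the two compounds, even though ethoxymethoxy brings 5 heavy atoms and 2 hydrogen-bond acceptors, which shows that this position can carry a chain of this size without a difference that can be read in this assay, unlike the exchanges of the whole group, two of which moved the number by more. No measurement shown here accounts for this outcome, and nothing supports an explanation for it.

The compounds shown leave open whether the same holds for other groups on this carbon, such as a hydroxyl, an amine, a carboxylic acid or a longer all-carbon chain, any of which might separate from compound 3 where ethoxymethoxy does not. They also leave open whether the same extension would read alike on a group such as thiophen-2-yl.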